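Halogens in Place of Hydroxy Groups on the Hydrazone Aryl Ring

The source may hold more compounds than are shown below. What is called first, only, known or untested is meant among the compounds shown, and "the series" means these compounds.

Measured compounds:
- compound 1 `CN(C)CCn1cnnc1-c1cc(Oc2ccc(NC(=O)N/N=C/c3cccc(O)c3)cc2F)ccn1`: 330 nM
- compound 2 `CN(C)CCn1cnnc1-c1cc(Oc2ccc(NC(=O)N/N=C/c3ccc(O)c(O)c3)cc2F)ccn1`: 1890 nM
- compound 3 `CN(C)CCn1cnnc1-c1cc(Oc2ccc(NC(=O)N/N=C/c3ccc(O)c(Br)c3)cc2F)ccn1`: 450 nM

In a functional assay on HT-29 cells (Homo sapiens) for cytotoxicity, read by MTT assay, with a stated time of 72 h (on this read-out lower numbers stand for stronger inhibition and higher numbers for weaker inhibition), compound 2 has the highest number of the three. The new analogue, compound 4 `CN(C)CCn1cnnc1-c1cc(Oc2ccc(NC(=O)N/N=C/c3ccc(Cl)cc3Cl)cc2F)ccn1`, carries 2,4-dichlorophenyl in place of 3,4-dihydroxyphenyl on a carbon with a double bond to nitrogen. Within the data shown here, two measured steps bear on this change. Adding a hydroxy gave a 5.7-fold higher number from compound 1 to compound 2 (0.76 log units; beyond the scatter), while putting bromo in place of hydroxy gave a 4.2-fold lower number from compound 2 to compound 3 (0.62 log units; beyond the scatter). Compound 4 removes both hydroxy groups and brings in two chlorines, so a lower number than compound 2 is expected, roughly back to where compound 1 and compound 3 stand. The expected step is a 4.7-fold lower number from compound 2 to compound 4 (0.67 log units; beyond the scatter). Compound 4 is therefore estimated at 400 nM, within a range from 150 nM to 1200 nM.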

Compound 4, half-maximal inhibitory concentration: 390 nM
The estimate for compound 4 lay 1.0-fold (0.01 log units) above the measured number; measured number inside the range.
By their numbers in this assay, from the lowest: compounds 1, 4 and 3 (each within the scatter of the next); then compound 2.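

In this assay, putting 2,4-dichlorophenyl in place of 3,4-dihydroxyphenyl on this carbon gives a clear shift (a 4.8-fold lower number from compound 2 to compound 4 (0.69 log units; beyond the scatter)), so a ring with no hydroxy group at all can reach the level of the rings carrying one. That ring does not separate from either of those rings (a 1.2-fold lower number from compound 3 to compound 4 (0.06 log units; within the scatter); a 1.2-fold higher number from compound 1 to compound 4 (0.07 log units; within the scatter)). Nothing measured here explains this result.

From the compounds shown here alone, the two chlorines enter together, so the share of each remains unknown. Going by these compounds, whether an amine or a carboxylic acid on this ring would hold the same level also remains open.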